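The compounds below may be only part of what the source reports. "The series", "measured", "known", "first", "only" and "open" are said of these compounds alone.

In a functional assay on MCF7 cells (Homo sapiens) for inhibition, read by MTT assay, with a stated time of 3 days (on this read-out lower numbers stand for stronger inhibition and higher numbers for weaker inhibition), compound 1 `COc1cc(-c2nc3ccccc3s2)ccc1OCC(=O)NNC(=O)CN[C@@H](CS)C(=O)O` gives 1230 nM and compound 2 `COc1cc(-c2nc3ccccc3s2)ccc1OCC(=O)NNC(=O)CN[C@@H](CS(=O)(=O)O)C(=O)O` gives 1870 nM, so compound 2 has a single neighbour on the scale, and the scatter cannot separate the two. Compound 3 `COc1cc(-c2nc3ccccc3s2)ccc1OCC(=O)NNC(=O)CN1CCC[C@H]1C(=O)O` differs from compound 2 by 2-carboxypyrrolidin-1-yl in place of (1-carboxy-2-sulfoethyl)amino on a saturated chain carbon bound to a carbonyl carbon. Among the measured compounds shown here, the only measured step, a 1.5-fold higher number from compound 1 to compound 2 (0.18 log units; within the scatter), changed just part of the group that leaves here. It is therefore a weak guide, and no step beyond the scatter is expected in this assay. The estimated step is a 1.2-fold lower number from compound 2 to compound 3 (0.10 log units; within the scatter). Compound 3 is thus expected at 1500 nM, with an estimated range of 500 nM to 4500 nM.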

Compound 3, half-maximal inhibitory concentration: 840 nM
For compound 3 the middle estimate is 1.8-fold (0.25 log units) above the measured one, within the range that was stated.
By their numbers in this assay, from the lowest: compounds 3, 1 and 2 (each within the scatter of the next, the first and the last beyond it).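

In this assay, among the compounds shown here, putting 2-carboxypyrrolidin-1-yl in place of (1-carboxy-2-sulfoethyl)amino gives a 2.2-fold lower number from compound 2 to compound 3 (0.35 log units; beyond the scatter) and is the first change at this position to pass the scatter, though modestly. Set against (1-carboxy-2-sulfanylethyl)amino, the same ring gives a 1.5-fold lower number from compound 1 to compound 3 (0.17 log units; within the scatter) and no clear difference, so the gain appears only against the sulfo compound. Nothing at hand explains this shift. Still open, going by these compounds, is whether the ring itself matters or the acid on it. A plain pyrrolidin-1-yl without the carboxylic acid, or a six-membered piperidine ring carrying it, would help separate the two.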